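Removing the Ethylamino Group: From Compound 2 to Compound 3

This account rests on a few compounds, and the source may have more. Where it says the series, first, only, none or still open, it means among the compounds named here.

Compound 1 `CCOc1cc(-c2cccnc2)ccc1C(N)=O`: 2200 nM
Compound 2 `CCNc1cc(-c2cccnc2)ccc1C(N)=O`: 58000 nM

In an assay on cells for inhibition of MAP kinase-interacting serine/threonine-protein kinase 1 (Homo sapiens), read by mobility shift assay, with stated times of 10 min and 60 min, in the presence of a further agent that is not named here (a lower number here means a stronger inhibitor, a higher number a weaker inhibitor), compound 1 gives 2200 nM and compound 2 gives 58000 nM. Compound 2 therefore stands at the higher of the two numbers, the weaker inhibitor, separated from compound 1 by a 26-fold higher number from compound 1 to compound 2 (1.42 log units; beyond the scatter). For the measured compounds named here, that single step, ethylamino in place of ethoxy on an aromatic carbon, is the only measured comparison and it is large.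

Compound 3 `NC(=O)c1ccc(-c2cccnc2)cc1` has not been measured. It differs from compound 2 by hydrogen in place of ethylamino on an aromatic carbon. Going by the values given here, the one measured step bears on this change only loosely: it shows that the group on this aromatic carbon can move the number a great deal, but it does not say what happens when the group is gone entirely. Compound 3 is therefore expected to land between the two measured numbers, a step of a 3.9-fold lower number from compound 2 to compound 3 (0.59 log units; beyond the scatter), with an estimate of 15000 nM and a range from 3000 nM to 80000 nM.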

Compound 3, half-maximal inhibitory concentration: 8800 nM
Estimate against measurement, compound 3: 1.7-fold (0.23 log units) above, and the stated range covers the measured number.
By their numbers in this assay, from the lowest: compound 1; then compound 3; then compound 2.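

In this assay, hydrogen in place of ethylamino gives a 6.6-fold lower number from compound 2 to compound 3 (0.82 log units; beyond the scatter) and the number falls, while hydrogen in place of ethoxy gives a 4.0-fold higher number from compound 1 to compound 3 (0.60 log units; beyond the scatter) and the number rises. With hydrogen as the reference point, the two groups therefore act in opposite directions at this position: ethoxy goes with a stronger inhibitor and ethylamino with a weaker one. For the compounds shown here, a group on this aromatic carbon can thus either help or harm, and the core still gives a measurable number with no group there at all, which the single earlier step could not show. No measurement available here explains the opposite directions. On these data alone, it remains open how a methoxy group, a longer chain such as propoxy, or a hydroxyl group at this position would compare with ethoxy and hydrogen.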